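From Sulfamoyl to Dimethylsulfamoyl, Starting at a Limit

A few compounds are considered here, and "the series" means these few. Any claim that something is new, unique, unknown or untested is made for them only; others in the source may bear on it.

Measured compounds in a functional assay on the whole organism (strain Sprague-Dawley) for inhibition, with Rattus norvegicus as the target, with a stated time of 10 min; a higher number here means that more compound is needed for the effect, a lower number that less compound is needed:
- Compound 1 `CCOc1ccccc1-c1ncc(C(=O)O)c(=O)[nH]1`: 0.5 mg/kg
- Compound 2 `CCOC(=O)C(=O)Nc1ccc(OCC)c(-c2ncc(C(=O)O)c(=O)[nH]2)c1`: 25 mg/kg
- Compound 3 `CCOc1ccc(S(N)(=O)=O)cc1-c1ncc(C(=O)O)c(=O)[nH]1`: > 50 mg/kg (a limit of the assay, not a number)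

Going by these compounds, compound 3 gives only a limit, > 50 mg/kg, so its true position is unknown. Compound 4 `CCOc1ccc(S(=O)(=O)N(C)C)cc1-c1ncc(C(=O)O)c(=O)[nH]1` has dimethylamino in place of amino on a sulfonyl sulfur, turning sulfamoyl into dimethylsulfamoyl (dimethylamino in place of amino on a sulfonyl sulfur).

For the measured compounds named here, no measured step makes this exact change, so the evidence is indirect. Sulfamoyl in place of hydrogen on an aromatic carbon gave an at least 100-fold higher number from compound 1 to compound 3 (2.00 log units; beyond the scatter). The ((ethoxycarbonyl)carbonyl)amino group in that place gave a 50-fold higher number from compound 1 to compound 2 (1.70 log units; beyond the scatter). Both steps are large and point the same way. The comparison of the two substituted compounds gives an at least 2.0-fold higher number from compound 2 to compound 3 (0.30 log units; that floor lies within the scatter), which does not separate them.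

Compound 4 keeps a substituent in that place, so it is expected to remain far from compound 1 in this assay, and it may also return only a limit. The expected change is a number no higher from compound 3 to compound 4 (the limit leaves the size open), which would be no step beyond the scatter. For compound 4 the estimated value is 50 mg/kg, with an expected range from 15 mg/kg to 100 mg/kg.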

Compound 4, dose for 50% inhibition: > 50 mg/kg
Compound 4 was reported as a limit (the forecaster's own chance of this, stated with the estimate: 50%); the middle value lies on the limit itself.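

In this assay compound 4 gives > 50 mg/kg, which is a limit of the assay and not a number. Dimethylsulfamoyl in place of hydrogen on an aromatic carbon gives an at least 100-fold higher number from compound 1 to compound 4 (2.00 log units; beyond the scatter), so the large loss seen with sulfamoyl in that place persists when dimethylamino replaces amino on the sulfonyl sulfur. Dimethylsulfamoyl in place of ((ethoxycarbonyl)carbonyl)amino gives an at least 2.0-fold higher number from compound 2 to compound 4 (0.30 log units; that floor lies within the scatter), so compound 4 is not separated from compound 2 in this assay, and all three substituted compounds remain far from compound 1.

Going by these compounds, whether dimethylamino in place of amino on the sulfonyl sulfur changes the dose at all cannot be read, because compound 3 and compound 4 both rest on the same limit: the limit of > 50 mg/kg in this assay, at which 2 of the 4 values shown sit. It also remains open whether a methylamino group on the sulfonyl sulfur, or a methyl or methoxy group in place of the sulfonyl group on the aromatic carbon, would bring the dose back towards that of compound 1.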